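The source may report more compounds than this note shows. Statements on the series, on what has been measured and on what is new or still open speak of the compounds shown alone.

Measured so far in a functional assay on the whole organism (strain Wistar Albino) for inhibition, with Rattus norvegicus as the target, read by paw edema, with a stated time of 1 h, at a dose of 20 mg/kg; on this read-out higher numbers stand for more inhibition at the one dose given (going by the name of the read-out) and lower numbers for less inhibition:

Compound 1, `COc1ccc(Cc2nnc3n2NC(c2ccco2)S3)cc1OC`, gives 12%.
Compound 2, `Cc1occc1-c1nnc2n1NC(c1ccco1)S2`, gives 16.4%.
Compound 3, `COc1ccc(Cc2nnc3n2NC(c2ccc[nH]2)S3)cc1OC`, gives 13.2%.

All three compounds share a fused core carrying a five-membered aromatic ring on a saturated ring carbon. Compound 3 differs from compound 1 by one change, (1H-pyrrol-2-yl in place of furan-2-yl on a saturated ring carbon), and this change made a step of a number 1.2 percentage points higher from compound 1 to compound 3 (within the scatter). The difference between the core of compound 1 and the core of compound 2 is not broken down here; the two values lie within the usual scatter of each other.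

Compound 4, `Cc1occc1-c1nnc2n1NC(c1ccc[nH]1)S2`, has not yet been measured. It differs from compound 2 by 1H-pyrrol-2-yl in place of furan-2-yl on a saturated ring carbon, the same change as from compound 1 to compound 3, at the same place. Because the earlier step was a number 1.2 percentage points higher from compound 1 to compound 3 (within the scatter), a step of about a number 1.2 percentage points higher from compound 2 to compound 4 (within the scatter) is expected from compound 2 to compound 4 in this assay. Compound 4 is therefore estimated at 17.6%, expected to fall between 9% and 26%.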

Compound 4, a percentage reported as inhibition, in the whole organism at one dose (the size of the read-out at that dose, not a potency): 13.7%
Estimate against measurement, compound 4: 3.9 percentage points above, and the stated range covers the measured number.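

In this assay, 1H-pyrrol-2-yl in place of furan-2-yl on the core of compound 2 gives a step of a number 2.7 percentage points lower from compound 2 to compound 4 (within the scatter). Set beside the same change on the core of compound 1, this step does not differ from the earlier one by more than the scatter allows: the same change on two cores in this assay, a number 1.2 percentage points higher (within the scatter) from compound 1 to compound 3 and a number 2.7 percentage points lower (within the scatter) from compound 2 to compound 4, 3.9 percentage points apart, within the scatter of two such steps. Both steps are small, so the data fit a change that does little on either core, but they do not show that it has any real effect of its own, in either direction, or how it would behave on a third core.

The group on the saturated ring carbon is only ever furan-2-yl or 1H-pyrrol-2-yl here. From the compounds shown here alone, whether a phenyl ring or a chain ending in an amine at that place would move the number beyond the scatter remains open.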